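A few compounds are considered here, and "the series" means these few. Any claim that something is new, unique, unknown or untested is made for them only; others in the source may bear on it.

Measured compounds in the series:
- Compound 1 `CCOc1ccc(-c2nn3cc(-c4cccc(N)c4)nc3s2)cc1`: in a functional assay on FM3A cells (Mus musculus) for inhibition, read by cell counting, with a stated time of 2 days (on this read-out higher numbers stand for weaker inhibition and lower numbers for stronger inhibition), compound 1 gives >= 250000 nM, which is a limit of the assay and not a number.
- Compound 2 `C=C(Br)C(=O)Nc1cccc(-c2cn3nc(-c4ccccc4)sc3n2)c1`: compound 2 gives 900 nM.
- Compound 3 `C=C(Br)C(=O)Nc1cccc(-c2cn3nc(-c4ccc(OCC)cc4)sc3n2)c1`: compound 3 gives 1100 nM.

Compound 3 stands as the higher of the two numbers; its nearest neighbour is compound 2, and the step of a 1.2-fold higher number from compound 2 to compound 3 (0.09 log units; within the scatter) lies within the scatter, so no order between the two can be claimed. Going by the values given here, the only other value, that of compound 1, is a limit, as recorded in the limit of >= 250000 nM in this assay, at which 1 of the 3 values shown sits; the step of an at least 220-fold lower number from compound 1 to compound 3 (2.35 log units; beyond the scatter) is the one large effect seen, and it comes from the (1-bromoethenyl)carbonyl on the nitrogen, which compound 4 keeps.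

Compound 4 `C=C(Br)C(=O)Nc1cccc(-c2cn3nc(-c4cccs4)sc3n2)c1` differs from compound 3 in thiophen-2-yl in place of 4-ethoxyphenyl on an aromatic carbon. Among the compounds with values here, the only measured step at that aryl is the change from compound 2 to compound 3, ethoxy in place of hydrogen, which stayed within the scatter; no measured step exchanges the whole ring. The expectation for compound 4 is therefore a step of a 1.1-fold higher number from compound 3 to compound 4 (0.04 log units; within the scatter) in this assay, not beyond the scatter, in either direction. Compound 4 is thus estimated at 1200 nM, with a range from 400 nM to 4000 nM.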

Compound 4, half-maximal inhibitory concentration: 370 nM
Compound 4: the middle estimate sits 3.2-fold (0.51 log units) above what was measured, outside the stated range (below it).
By their numbers in this assay, from the lowest: compound 4; then compounds 2 and 3 (each within the scatter of the next). At a limit, above all of these: compound 1.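

In this assay the aryl group on the aromatic carbon of the five-membered aromatic ring with 2 nitrogen and 1 sulfur does affect the read-out: thiophen-2-yl gives a 3.0-fold lower number from compound 3 to compound 4 (0.47 log units; beyond the scatter) and a 2.4-fold lower number from compound 2 to compound 4 (0.39 log units; beyond the scatter), both modest but beyond the scatter. Until now this position had only the step of a 1.2-fold higher number from compound 2 to compound 3 (0.09 log units; within the scatter), so adding ethoxy to the phenyl ring had shown no change, whereas exchanging the whole ring does show one, though this rests on the single thiophen-2-yl compound. Nothing among the measurements shown accounts for this difference.

From the compounds shown here alone, it remains open whether the lower number belongs to the sulfur of the ring or to the five-membered ring as such, which furan-2-yl or thiophen-3-yl in the same place would separate, and whether a methyl group or an amine on the thiophene ring would be tolerated. Also open is how much of the number of compound 4 depends on the (1-bromoethenyl)carbonyl, since the free amine is shown only with the 4-ethoxyphenyl group.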